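This account rests on a few compounds, and the source may have more. Where it says the series, first, only, none or still open, it means among the compounds named here.

Within this series the shared core carries a variable group on the carbonyl carbon. In a functional assay on the whole organism for inhibition, with Rattus norvegicus as the target, read by cytopathic effect and paw edema, at a dose of 100 mg/kg by the oral route (a higher number here means more inhibition at the dose given (going by the name of the read-out), a lower number less inhibition), compound 1 `CCOC(=O)c1c(O)c2cccnc2n(-c2ccccc2)c1=O` gives 15.5%, compound 2 `CCCCNC(=O)c1c(O)c2cccnc2n(-c2ccccc2)c1=O` gives 20.4% and compound 3 `Cc1cccc(NC(=O)c2c(O)c3cccnc3n(-c3ccccc3)c2=O)c1` gives 4.5%, the lowest of the three, the steps being a number 11 percentage points lower from compound 1 to compound 3 (beyond the scatter) and a number 15.9 percentage points lower from compound 2 to compound 3 (beyond the scatter). Compound 4 `O=C(Nc1cccc([N+](=O)[O-])c1)c1c(O)c2cccnc2n(-c2ccccc2)c1=O` differs from compound 3 by nitro in place of methyl on an aromatic carbon. Within the data shown here, no measured step changes a group on that aromatic ring; the steps that come nearest exchange the whole group on the carbonyl carbon, and a number 4.9 percentage points higher from compound 1 to compound 2 (within the scatter) stayed within the scatter while the moves to compound 3 were modest. A step of a number 3.5 percentage points higher from compound 3 to compound 4 (within the scatter) in this assay is therefore expected, no larger than the scatter. Compound 4 is estimated at 8%, within -5% to 22%.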

Compound 4, a percentage reported as inhibition, in the whole organism at one dose (the size of the read-out at that dose, not a potency): 7.4%
Compound 4: the middle estimate sits 0.6 percentage points above what was measured, and the stated range covers the measured number.
By their numbers in this assay, from the lowest: compounds 3, 4, 1 and 2 (each within the scatter of the next, the first and the last beyond it).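

Nitro in place of methyl on the aromatic carbon meta to a large group (a number 2.9 percentage points higher from compound 3 to compound 4 (within the scatter)) does not separate the two compounds in this assay. The gap to the butyl amide persists with the 3-nitrophenyl group (a number 13 percentage points lower from compound 2 to compound 4 (beyond the scatter)). Against the ethoxy compound, however, the (3-nitrophenyl)amino group stays within the scatter (a number 8.1 percentage points lower from compound 1 to compound 4 (within the scatter)), whereas the (3-methylphenyl)amino group did not. Nothing available explains these steps. As far as these compounds go, whether an amine or a carboxylic acid on that aromatic ring, or a longer chain in place of butyl, would shift the inhibition remains open.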